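This account rests on a few compounds, and the source may have more. Where it says the series, first, only, none or still open, it means among the compounds named here.

Measured so far in a functional assay on HT-22 cells (Mus musculus), read by MTT assay; on this read-out lower numbers stand for higher toxicity in this test and higher numbers for lower toxicity in this test: compound 1 `CC(C)CNC1Oc2ccc(C(=O)c3ccccc3)c(O)c2NC1(C)C`, compound 2 `CC1(C)Nc2c(ccc(C(=O)c3ccccc3)c2O)OC1N1CCCCC1`, compound 3 `CN(CC1OCCO1)C1Oc2ccc(C(=O)c3ccccc3)c(O)c2NC1c1ccccc1`. Compound 1 gives 45 uM. Compound 2 gives 72 uM. Compound 3 reaches only the assay limit, > 250 uM, and no number.

Among the measured compounds shown here, the only measured step on the saturated ring carbon, a 1.6-fold higher number from compound 1 to compound 2 (0.20 log units; within the scatter), stays within the scatter. Compound 4 `COC(CNC1Oc2ccc(C(=O)c3ccccc3)c(O)c2NC1c1ccccc1)OC` differs from compound 3 by (2,2-dimethoxyethyl)amino in place of ((1,3-dioxolan-2-yl)methyl)(methyl)amino on a saturated ring carbon, again a change of the amino substituent on that carbon. On this evidence no step beyond the scatter is expected in this assay, in either direction; the estimated step is a number no higher from compound 3 to compound 4 (the limit leaves the size open). Compound 3 sits at the limit of > 250 uM in this assay, at which 1 of the 3 values shown sits. Compound 4 is therefore expected to stay near that limit, estimated at 250 uM with a range from 110 uM to 500 uM.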

Compound 4, half-maximal toxic concentration: > 250 uM
Compound 4 ended at the assay's limit; the forecaster's own chance of this, stated with the estimate: 60%; the middle value sits exactly at the limit.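

Compound 3 and compound 4 both end at a limit in this assay, not at a number, so no step between them can be read: the limit of > 250 uM in this assay, at which 2 of the 4 values shown sit.

The compounds shown leave open whether (2,2-dimethoxyethyl)amino in place of ((1,3-dioxolan-2-yl)methyl)(methyl)amino changes the read-out at all.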